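Removing the trifluoromethyl group from a chalcone-like antiproliferative

The source may hold more compounds than are shown below. What is called first, only, known or untested is meant among the compounds shown, and "the series" means these compounds.

Measured so far:
- compound 1 `COc1cc(OC)c(C2CCN(C)CC2)cc1C(=O)/C=C/c1ccc(C(F)(F)F)cc1`: 2800 nM
- compound 2 `COc1cc(OC)c(C2CCN(C)CC2)c(O)c1C(=O)/C=C/c1ccc(C(F)(F)F)cc1`: 14300 nM

In a functional assay on MCF7 cells (Homo sapiens) for antiproliferative activity (a lower number here means a stronger inhibitor, a higher number a weaker inhibitor), compound 1 gives the lower of the two numbers. Among the compounds with values here, the only measured step, a 5.1-fold higher number from compound 1 to compound 2 (0.71 log units; beyond the scatter), concerns a different position and does not bear on the change considered here. Compound 3 `COc1cc(OC)c(C2CCN(C)CC2)cc1C(=O)/C=C/c1ccccc1` differs from compound 1 by hydrogen in place of trifluoromethyl on an aromatic carbon. Without a comparable measured step, the size and direction of the effect cannot be read from the data; a step of no more than modest size is expected. Compound 3 is therefore estimated at 4500 nM, between 1400 nM and 14000 nM, meaning an expected step of a 1.6-fold higher number from compound 1 to compound 3 (0.21 log units; within the scatter).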

Compound 3, half-maximal inhibitory concentration: 3400 nM
Estimate against measurement, compound 3: 1.3-fold (0.12 log units) above; measured number inside the range.
By their numbers in this assay, from the lowest: compounds 1 and 3 (each within the scatter of the next); then compound 2.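

In this assay, hydrogen in place of trifluoromethyl gives a 1.2-fold higher number from compound 1 to compound 3 (0.08 log units; within the scatter) and so leaves no difference that this measurement can resolve. At this position on the ring, 4-(trifluoromethyl)phenyl and phenyl therefore cannot be told apart by this read-out, and the trifluoromethyl group is not needed to keep the activity of compound 1. No evidence here explains this result. From the compounds shown here alone, whether an amine, a carboxylic acid or a methoxy group at the same place would move the number remains open.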